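Azetidine replaces cyclopropylmethylamine on the benzylic carbon

The source may hold more compounds than are shown below. What is called first, only, known or untested is meant among the compounds shown, and "the series" means these compounds.

Compound 1 `CC(C)(C)NCc1ccc2c(c1)CCC[C@H]2NC(=O)C[C@@H]1CCCCN1S(=O)(=O)c1cccc(Cl)c1`: 120 nM
Compound 2 `Cc1ccc(S(=O)(=O)N2CCCC[C@H]2CC(=O)N[C@@H]2CCCc3cc(CNC(C)(C)C)ccc32)cc1C(F)(F)F`: 11 nM
Compound 3 `O=C(C[C@@H]1CCCCN1S(=O)(=O)c1cccc(C(F)(F)F)c1)N[C@@H]1CCCc2cc(CNCC3CC3)ccc21`: 16 nM

In an assay on isolated protein for inhibition of B1 bradykinin receptor (Homo sapiens) (a lower number here means a stronger inhibitor, a higher number a weaker inhibitor), compound 3 stands second highest of the three numbers; its nearest neighbour is compound 2, within the scatter, while compound 1 lies furthest away, beyond the scatter. For the measured compounds named here, the one step measured so far, an 11-fold lower number from compound 1 to compound 2 (1.04 log units; beyond the scatter), concerns the group on the sulfonyl sulfur and is large. Compound 4 `O=C(C[C@@H]1CCCCN1S(=O)(=O)c1cccc(C(F)(F)F)c1)N[C@@H]1CCCc2cc(CN3CCC3)ccc21` differs from compound 3 in another place: azetidin-1-yl in place of (cyclopropylmethyl)amino on a saturated chain carbon bound to an aromatic carbon. No measured step touches this benzylic amine, so the step from compound 3 to compound 4 has no direct precedent among these compounds; the measured step only shows that the sulfonyl aryl region is sensitive, which does not speak to this change. A modest change, if any, is expected for compound 4, most likely a small loss, a 1.6-fold higher number from compound 3 to compound 4 (0.19 log units; within the scatter). Compound 4 is therefore estimated at 25 nM, with a range from 8 nM to 80 nM.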

Compound 4, half-maximal inhibitory concentration: 1100 nM
Estimate against measurement, compound 4: 44-fold (1.64 log units) below, outside the stated range (above it).
By their numbers in this assay, from the lowest: compounds 2 and 3 (each within the scatter of the next); then compound 1; then compound 4.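

In this assay, the group on the saturated chain carbon bound to an aromatic carbon turns out to matter strongly: azetidin-1-yl in place of (cyclopropylmethyl)amino gives a 69-fold higher number from compound 3 to compound 4 (1.84 log units; beyond the scatter). For the compounds shown here, until now, the only measured sensitivity lay in the group on the sulfonyl sulfur, so this is the first sign that this second site also governs the value. The step replaces a group with 1 hydrogen-bond donor by one with 0 and also changes the ring, and no data here explain the loss.

The compounds shown leave open whether the loss follows the hydrogen on the nitrogen or the ring itself. An N-methyl-(cyclopropylmethyl)amino group and a cyclobutylamino group would separate these two changes.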